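The compounds below may be only part of what the source reports. "The series", "measured", "known", "first", "only" and "open" are said of these compounds alone.

Working notes on the oxime ether series sharing the core of compound 1 `Nc1ncnc(Oc2ccc(NC(=O)C3(C(=O)Nc4ccc(F)cc4)CC3)cc2F)c1/C=N/OCCO`. In a physicochemical assay for lipophilicity, using the shake flask method (on this read-out lower numbers stand for lower lipophilicity and higher numbers for higher lipophilicity), compound 1 gives 2.37. Compound 2 `Nc1ncnc(Oc2ccc(NC(=O)C3(C(=O)Nc4ccc(F)cc4)CC3)cc2F)c1/C=N/OCC(=O)N1CCOCC1` gives 2.1 and compound 3 `COCCCO/N=C/c1c(N)ncnc1Oc1ccc(NC(=O)C2(C(=O)Nc3ccc(F)cc3)CC2)cc1F` gives 3.18. Compound 2 stands lowest of the three numbers: the nearest is compound 1, and the step of a number 0.27 log units lower from compound 1 to compound 2 (within the scatter); the furthest is compound 3, with a number 1.08 log units higher from compound 2 to compound 3 (beyond the scatter). The remaining measured step, a number 0.81 log units higher from compound 1 to compound 3 (beyond the scatter), also runs toward compound 3.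

Compound 4 `Nc1ncnc(Oc2ccc(NC(=O)C3(C(=O)Nc4ccc(F)cc4)CC3)cc2F)c1/C=N/OC1CCCC1` has not yet been measured in this assay. Relative to compound 2 it carries cyclopentyl in place of ((morpholin-4-yl)carbonyl)methyl on an oxygen.

Among the compounds with values here, two measured steps bear on this change. Replacing the (morpholin-4-yl)carbonyl with 2-methoxyethyl produced a number 1.08 log units higher from compound 2 to compound 3 (beyond the scatter), and replacing hydroxy with methoxymethyl gave a number 0.81 log units higher from compound 1 to compound 3 (beyond the scatter). Both went upward once the polar end of the chain was removed. Cyclopentyl removes both hydrogen-bond acceptors of the leaving group and adds no acceptor of its own, and it brings only carbon, so a step at least as large as that to compound 3 is expected, in the upward direction and well beyond the scatter. The expected step is a number 1.90 log units higher from compound 2 to compound 4 (beyond the scatter). Compound 4 is therefore estimated at 4, with a likely range from 3.4 to 4.6.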

Compound 4, partition coefficient: 4.27
For compound 4 the middle estimate is 0.27 log units below the measured one; the range from low to high includes it.
By their numbers in this assay, from the lowest: compounds 2 and 1 (each within the scatter of the next); then compound 3; then compound 4.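

In this assay, cyclopentyl on this oxygen puts compound 4 at the top of the series, with a number 2.17 log units higher from compound 2 to compound 4 (beyond the scatter) and a number 1.09 log units higher from compound 3 to compound 4 (beyond the scatter) as well as a number 1.90 log units higher from compound 1 to compound 4 (beyond the scatter) on the same read-out. The earlier spread, a number 1.08 log units higher from compound 2 to compound 3 (beyond the scatter) at its widest, therefore did not mark the upper end for this position, and a group of carbon only, with 0 hydrogen-bond acceptors, extends it beyond every group carrying a hetero atom. The widest step in the series also comes with the smaller group: cyclopentyl has 5 heavy atoms where ((morpholin-4-yl)carbonyl)methyl has 9, so across compound 2 and compound 4 a higher number does not go with more heavy atoms.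

On these data alone, an open pentyl chain on the same oxygen would separate the effect of the ring from that of an all-carbon group, and a chain ending in an amine or a carboxylic acid would probe the lower end of the range, so both questions remain open. The data shown offer no measured explanation for the size of these steps.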